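From trifluoromethyl to methyl on an aromatic carbon

The source may hold more compounds than are shown below. What is called first, only, known or untested is meant among the compounds shown, and "the series" means these compounds.

Measured in a functional assay on HeLa cells (Homo sapiens) for inhibition, read by sulforhodamine B assay; a higher number here means a weaker inhibitor, a lower number a stronger inhibitor:
Compound 1 `CCCc1ccc(NC2=CC(=O)c3nc4n(c3C2=O)[C@H]2OC[C@@H](O)[C@H]2OC4)cc1`: 4990 nM
Compound 2 `O=C1C=C(Nc2ccc(C(F)(F)F)cc2)C(=O)c2c1nc1n2[C@H]2OC[C@@H](O)[C@H]2OC1`: > 8000 nM

Compound 2 gives no number, only a limit of the assay, > 8000 nM. This is the limit of > 8000 nM in this assay, at which 1 of the 2 values shown sits. Compound 3 `Cc1ccc(NC2=CC(=O)c3nc4n(c3C2=O)[C@H]2OC[C@@H](O)[C@H]2OC4)cc1` carries methyl in place of trifluoromethyl on an aromatic carbon. Within the data shown here, one measured step bears on this change, an at least 1.6-fold higher number from compound 1 to compound 2 (0.20 log units; that floor lies within the scatter), and its floor lies within the scatter. Among the measured compounds shown here, with compound 1 at 4990 nM as the only number, a small move to a lower number is expected, possibly none beyond the scatter. The expected step is an at least 1.4-fold lower number from compound 2 to compound 3 (0.16 log units; that floor lies within the scatter). In this assay compound 3 is estimated at 5500 nM, within an expected range of 2500 nM to 12000 nM.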

Compound 3, half-maximal inhibitory concentration: 3860 nM
Compound 3: middle estimate off by 1.4-fold (0.15 log units), on the high side; the range from low to high includes it.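

Methyl in place of trifluoromethyl gives an at least 2.0-fold lower number from compound 2 to compound 3 (0.31 log units; beyond the scatter) in this assay, the first step at this position that clears the scatter, so these two groups can be told apart here. That step is only a floor, since compound 2 carries a limit and not a number: the limit of > 8000 nM in this assay, at which 1 of the 3 values shown sits. Methyl in place of propyl gives a 1.3-fold lower number from compound 1 to compound 3 (0.11 log units; within the scatter), so these two groups cannot be told apart here. Going by these compounds, how far compound 2 truly lies from the others stays open. So does the effect of a chlorine, a hydroxyl or an amine at this position.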